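The source may hold more compounds than are shown below. What is called first, only, known or untested is meant among the compounds shown, and "the series" means these compounds.

In an ADME assay on cells (Erythrocyte, Homo sapiens) for activation, read by hemolysis, with a stated time of 30 min, tested at 2.5 mM (a lower number here means a weaker effect, a higher number a stronger effect of the compound at the concentration tested), compound 1, `N=C(N)c1ccc(-c2ccc(-c3ccc(F)cc3)o2)o1`, gives 17.6%, and compound 2, `COc1ccc(-c2ccc(-c3ccc(C(=N)N)o3)o2)cc1`, gives 8.1%. The change between them is methoxy in place of fluoro on an aromatic carbon, and it gave a number 9.5 percentage points lower from compound 1 to compound 2 (within the scatter). Compound 3, `N=C(N)c1ccc(-c2ccc(-c3ccc(F)cc3)s2)s1`, gives 14% in this assay; the difference between its core and the core of compound 1 is not broken down here. Compound 4, `COc1ccc(-c2ccc(-c3ccc(C(=N)N)s3)s2)cc1`, has not yet been measured in this assay. It is related to compound 3 by methoxy in place of fluoro on an aromatic carbon, the same change as that from compound 1 to compound 2, at the same place. Beside the earlier step of a number 9.5 percentage points lower from compound 1 to compound 2 (within the scatter), a step of about a number 8 percentage points lower from compound 3 to compound 4 (within the scatter) is expected for compound 4, resting on that earlier step and on compound 3 having given 14%. Compound 4 is therefore estimated at 6%, between 0% and 16%.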

Compound 4, a percentage reported as activity, at one concentration (the size of the read-out at that concentration, not a potency): 41%
The estimate for compound 4 lay 35 percentage points below the measured number, and the stated range ends below it.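

In this assay, methoxy in place of fluoro on an aromatic carbon gave a number 27 percentage points higher from compound 3 to compound 4 (beyond the scatter). The same change therefore did not carry over from one core to the other with the same outcome: the same change on two cores in this assay, a number 9.5 percentage points lower (within the scatter) from compound 1 to compound 2 and a number 27 percentage points higher (beyond the scatter) from compound 3 to compound 4, 36.5 percentage points apart, beyond the scatter of two such steps This shows that a step measured on one core cannot be taken as a guide to the other in this series, but it does not show what in the two cores separates the outcomes, and two pairs say nothing about any further core. The compounds shown carry only fluoro and methoxy at this place on each core. They leave open how an amine, a carboxylic acid or a longer alkoxy chain there would read on either core.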